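The Same Chloro-to-Hydrogen Swap Seen Twice

The source may report more compounds than this note shows. Statements on the series, on what has been measured and on what is new or still open speak of the compounds shown alone.

Four close relatives share one core: a chain with a carbonyl linking an aromatic ring that carries a cyclic urea to a second aromatic ring. Compound 3 `O=C(/C=C/c1cccc(O)c1)c1cccc(-n2cc(-c3ccc(Cl)cc3)[nH]c2=O)c1` carries a 4-chlorophenyl on the urea ring, and compound 2 `O=C(/C=C/c1cccc(O)c1)c1cccc(-n2cc(-c3ccccc3)[nH]c2=O)c1` carries a plain phenyl there. In a functional assay on SNB-75 cells (Homo sapiens) for inhibition (a higher number here means a weaker inhibitor of growth, a lower number a stronger inhibitor of growth), compound 3 gives 1460 nM, while compound 2 gives 12100 nM. The change between them is hydrogen in place of chloro on an aromatic carbon, and it made an 8.3-fold higher number from compound 3 to compound 2 (0.92 log units; beyond the scatter).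

Compound 1 `COc1cc(/C=C/C(=O)c2cccc(-n3cc(-c4ccc(Cl)cc4)[nH]c3=O)c2)cc(OC)c1OC` has the 4-chlorophenyl but a different second aromatic ring; how its core differs from that of compound 3 is not broken down here. In this assay compound 1 is reported as "not active" (no number reported), so no number is attached to it.

Compound 4 `COc1cc(/C=C/C(=O)c2cccc(-n3cc(-c4ccccc4)[nH]c3=O)c2)cc(OC)c1OC` stands to compound 1 as compound 2 stands to compound 3: the change is hydrogen in place of chloro on an aromatic carbon, the same change at the same kind of place. Because compound 1 already gives "not active" (no number reported), the size of the step to compound 4 cannot be put in numbers, and the earlier step from compound 3 to compound 2 went toward weaker growth inhibition. Compound 4 is therefore expected to be a weak inhibitor, estimated at 50000 nM, with a likely range from 15000 nM to 150000 nM, and a fair chance that only a limit is reported.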

Compound 4, concentration for 50% growth inhibition: 4470 nM
Estimate against measurement, compound 4: 11-fold (1.05 log units) above; the whole stated range lies above it.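

No step can be read between compound 1 and compound 4: in this assay compound 4 gives 4470 nM while compound 1 gives "not active" (no number reported) and so has no number to compare. Nothing shown offers a measured reason for this result. The compounds shown leave open how large the change from 4-chlorophenyl to phenyl is on the core of compound 1.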